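The source may report more compounds than this note shows. Statements on the series, on what has been measured and on what is new or still open speak of the compounds shown alone.

The measured compounds:
compound 1, `CCC(C)/N=C(\NC#N)Nc1cccnc1`, 20 mg/kg
compound 2, `CC(C)C(/N=C(\NC#N)Nc1cccnc1)C(C)C`, 5 mg/kg
compound 3, `CC(C)(C)C(C)(C)/N=C(\NC#N)Nc1cccnc1`, 50 mg/kg

In a functional assay on the whole organism (blood, strain Wistar-Okamoto) with Rattus norvegicus as the target, with a stated time of 5 days (on this read-out lower numbers stand for an effect already at smaller amounts and higher numbers for an effect only at larger amounts of compound), compound 1 stands second highest of the three numbers. Its nearest neighbour is compound 3, whose number lies higher than that of compound 1 by a gap beyond the scatter, and its furthest is compound 2, whose number lies lower than that of compound 1 by a gap also beyond the scatter. Compound 4 is `N#CN/C(=N\Cc1ccco1)Nc1cccnc1`; set against compound 1, ((furan-2-yl)methyl in place of sec-butyl on a double-bonded nitrogen). Going by the values given here, no measured pair carries such a change; the direction is open. For compound 4 the step of no change at the digits printed from compound 1 to compound 4 (within the scatter) is expected to stay within the scatter. Compound 4 is estimated at 20 mg/kg, in a range from 5 mg/kg to 60 mg/kg.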

Compound 4, minimum effective dose: 20 mg/kg
Estimate against measurement, compound 4: no gap at the digits printed; measured number inside the range.
By their numbers in this assay, from the lowest: compound 2; then compounds 1 and 4 (each within the scatter of the next); then compound 3.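

In this assay, (furan-2-yl)methyl in place of sec-butyl on a double-bonded nitrogen gives no change at the digits printed from compound 1 to compound 4 (within the scatter). The earlier compounds shown here carry only open carbon chains at this place, whereas this step shows that a five-membered aromatic ring with a hydrogen-bond acceptor can stand there without a shift beyond the scatter. Nothing available explains why the read-out holds across this change. The compounds shown leave open whether benzyl, which has no ring oxygen, or a chain ending in an amine would give a similar read-out at this place.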